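Varying the amide substituent on a shared core

A few compounds are considered here, and "the series" means these few. Any claim that something is new, unique, unknown or untested is made for them only; others in the source may bear on it.

Compound 1 `C=CC(=O)Nc1ccc(-c2nccc3cc(OC)c(OC)cc23)cc1`: 12000 nM
Compound 2 `COc1cc2ccnc(-c3ccc(NC(=O)CCl)cc3)c2cc1OC`: 5000 nM

In an assay on heart for inhibition of phosphodiesterase 1 (Bos taurus), read by cAMP accumulation (a higher number here means a weaker inhibitor, a lower number a stronger inhibitor), compound 2 gives 5000 nM, the lowest of the two numbers, and the nearest is compound 1 with 12000 nM; the step of a 2.4-fold lower number from compound 1 to compound 2 (0.38 log units; beyond the scatter) is modest. Compound 3 `COC(=O)/C=C\C(=O)Nc1ccc(-c2nccc3cc(OC)c(OC)cc23)cc1` differs from compound 2 by 2-(methoxycarbonyl)ethenyl in place of chloromethyl on a carbonyl carbon. Among the compounds with values here, only that one measured step bears on this change, and it was modest. Since the entering group is again an ethenyl on the carbonyl carbon, compound 3 is expected to sit nearer compound 1 than compound 2. The step of a 1.6-fold higher number from compound 2 to compound 3 (0.20 log units; within the scatter) is therefore expected in this assay. The estimate for compound 3 is 8000 nM, within 3000 nM to 25000 nM.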

Compound 3, half-maximal inhibitory concentration: 5300 nM
For compound 3 the middle estimate is 1.5-fold (0.18 log units) above the measured one; the measured number falls inside the stated range.
By their numbers in this assay, from the lowest: compounds 2 and 3 (each within the scatter of the next); then compound 1.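

Placing 2-(methoxycarbonyl)ethenyl in place of chloromethyl on the carbonyl carbon adds heavy atoms, 6 against 2, yet leaves the reading in this assay within the scatter (a 1.1-fold higher number from compound 2 to compound 3 (0.03 log units; within the scatter)). Against vinyl, the same group gives a modest step (a 2.3-fold lower number from compound 1 to compound 3 (0.35 log units; beyond the scatter)), so an ethenyl on the carbonyl carbon does not by itself hold a compound at the level of compound 1. No measured evidence accounts for either step. Still open, as far as these compounds go, is whether a carboxylic acid in place of the methyl ester, or an amine on the carbonyl carbon, would read differently from these groups.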